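The source may hold more compounds than are shown below. What is called first, only, known or untested is meant among the compounds shown, and "the series" means these compounds.

Working notes on the series. In a functional assay on MCF7 cells (Homo sapiens) for inhibition, read by MTT assay, with a stated time of 48 h (on this read-out higher numbers stand for weaker inhibition of growth and lower numbers for stronger inhibition of growth), compound 1 (`COc1ccc(C(=O)N2N=C(c3ccccc3)CC2c2cn(C)c3ccccc23)cn1`) gives 4310 nM as its value, compound 2 (`COc1ccc2c(c1)c(C1CC(c3ccccc3)=NN1C(=O)c1cccnc1)cn2C`) gives 1160 nM and compound 3 (`COc1ccc2c(c1)c(C1CC(c3ccccc3)=NN1C(=O)c1ccc(OC)nc1)cn2C`) gives 990 nM on the same read-out. Compound 3 is therefore level with compound 2 within the scatter and well under compound 1.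

Compound 4 (`COc1ccc(C2=NN(C(=O)c3ccc(OC)nc3)C(c3cn(C)c4ccc(OC)cc34)C2)cc1`) departs from compound 3 by methoxy in place of hydrogen on an aromatic carbon in the change from phenyl to 4-methoxyphenyl, so it is again methoxy in place of hydrogen on an aromatic carbon. Two measured steps make this same exchange, both at other places on the molecule. One gives a 4.4-fold lower number from compound 1 to compound 3 (0.64 log units; beyond the scatter) and counts as modest, while the other gives a 1.2-fold lower number from compound 2 to compound 3 (0.07 log units; within the scatter) and stays within the scatter. Neither tests the new place, so they support only a small expected shift toward a lower number, quite possibly none beyond the scatter. The expected size is a 1.2-fold lower number from compound 3 to compound 4 (0.09 log units; within the scatter) in this assay by this reasoning. For compound 4 the estimated value is 800 nM with an expected range from 300 nM to 2200 nM on this read-out.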

Compound 4, concentration for 50% growth inhibition: 560 nM
Compound 4: middle estimate off by 1.4-fold (0.15 log units), on the high side, and the stated range covers the measured number.
By their numbers in this assay, from the lowest: compounds 4, 3 and 2 (each within the scatter of the next, the first and the last beyond it); then compound 1.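

For the compounds shown here, at this place, on an aromatic carbon of a six-membered aromatic ring of carbon only and para to a large group, phenyl to 4-methoxyphenyl gives a 1.8-fold lower number from compound 3 to compound 4 (0.25 log units; within the scatter) in this assay and so supplies the first direct reading of the exchange here. Of the three places now read for methoxy in place of hydrogen, only a 4.4-fold lower number from compound 1 to compound 3 (0.64 log units; beyond the scatter) lies beyond the scatter, while this step and a 1.2-fold lower number from compound 2 to compound 3 (0.07 log units; within the scatter) both stay within it. No measurement among these data bears on why the steps differ from place to place.

As far as these compounds go, whether another group at this place, such as an amine, a carboxylic acid or a longer chain, would give a step beyond the scatter remains open. Also open, from the compounds shown here alone, is whether the same exchange here would give a similar step on the cores of compound 1 or compound 2, which carry fewer methoxy groups.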